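The source may hold more compounds than are shown below. What is called first, only, known or untested is meant among the compounds shown, and "the series" means these compounds.

Series notes, values from a functional assay on A549 cells (Homo sapiens) for antiproliferative activity, read by MTT assay, with a stated time of 72 h; on this read-out higher numbers stand for weaker inhibition and lower numbers for stronger inhibition:

- compound 1 `O=C(Nc1ccc(Nc2nccc(NC3CC3)n2)cc1)Nc1ccc(Cl)c(C(F)(F)F)c1`: 18500 nM
- compound 2 `CCCNc1ccnc(Nc2ccc(NC(=O)Nc3ccc(Cl)c(C(F)(F)F)c3)cc2)n1`: 7320 nM
- compound 3 `O=C(Nc1ccc(Nc2nccc(Nc3ccccc3Cl)n2)cc1)Nc1ccc(Cl)c(C(F)(F)F)c1`: 18600 nM
- compound 4 `O=C(Nc1ccc(Nc2nccc(Nc3cccc(Cl)c3)n2)cc1)Nc1ccc(Cl)c(C(F)(F)F)c1`: not yet measured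

Compound 3 stands level with compound 1 and above compound 2, as a 1.0-fold higher number from compound 1 to compound 3 (0.00 log units; within the scatter) and a 2.5-fold higher number from compound 2 to compound 3 (0.41 log units; beyond the scatter) show. Compound 4 carries 3-chlorophenyl in place of 2-chlorophenyl on a nitrogen on an aromatic ring. Going by the values given here, no measured step covers this exchange directly. The nearest evidence is the set of swaps on the same nitrogen, and the largest of these is modest, a 2.5-fold lower number from compound 1 to compound 2 (0.40 log units; beyond the scatter). The much smaller chlorine shift is therefore expected to give no step beyond the scatter in this assay. The expected change is a 1.2-fold lower number from compound 3 to compound 4 (0.09 log units; within the scatter). For compound 4 the estimate is 15000 nM, with an expected range of 7000 nM to 30000 nM.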

Compound 4, half-maximal inhibitory concentration: 8050 nM
Compound 4: middle estimate off by 1.9-fold (0.27 log units), on the high side; low and high end bracket the measured number.
By their numbers in this assay, from the lowest: compounds 2 and 4 (each within the scatter of the next); then compounds 1 and 3 (each within the scatter of the next).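

The position of the chlorine on this nitrogen's aryl group matters (with a 2.3-fold lower number from compound 3 to compound 4 (0.36 log units; beyond the scatter)), so the 2-chlorophenyl result does not speak for chlorophenyl groups in general. The 3-chlorophenyl group stands level with propyl (with a 1.1-fold higher number from compound 2 to compound 4 (0.04 log units; within the scatter)) and gives a lower number than cyclopropyl (with a 2.3-fold lower number from compound 1 to compound 4 (0.36 log units; beyond the scatter)), so alkyl and aryl groups do not separate as classes here: each class has one member at either level. No available evidence accounts for this difference between the two chlorine positions.

Open, as far as these compounds go, is whether phenyl without chlorine sits nearer compound 3 or compound 4. Also open, from the compounds shown here alone, is whether a butyl chain on this nitrogen would extend the step from cyclopropyl to propyl.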